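The compounds below may be only part of what the source reports. "The series", "measured", "known", "first", "only" and "open" are said of these compounds alone.

Measured so far:
- compound 1, `COC(=O)/C=C/c1cccc(N(Cc2ccc(/C=C/c3cc(C(F)(F)F)cc(C(F)(F)F)c3)cc2)C(=O)C2CCCCC2)c1`: 1470 nM
- compound 2, `COC(=O)/C=C/c1cccc(N(Cc2ccc(/C=C/c3cc(C(F)(F)F)cc(C(F)(F)F)c3)cc2)C(=O)C(C)C)c1`: 1950 nM
- compound 3, `COC(=O)/C=C/c1cccc(N(Cc2ccc(-c3c(OC)cccc3OC)cc2)C(=O)C2CCCCC2)c1`: 77 nM

All values come from an assay on isolated protein with Bile acid receptor (Homo sapiens) as the target; a higher number here means that more compound is needed for the effect, a lower number that less compound is needed. Compound 1 and compound 2 share one core and differ at the acyl group: isopropyl in place of cyclohexyl on a carbonyl carbon. The resulting step, a 1.3-fold higher number from compound 1 to compound 2 (0.12 log units; within the scatter), is within the scatter, so on this core the two acyl groups are not told apart by this assay.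

Compound 3 carries a different core; the difference between its core and that of compound 1 is not broken down here. What the values show is that compound 3 stands at the lowest number of the three, well beyond the scatter from both compound 1 and compound 2.

Compound 4, `COC(=O)/C=C/c1cccc(N(Cc2ccc(-c3c(OC)cccc3OC)cc2)C(=O)C(C)C)c1`, is not yet measured. It sits on the core of compound 3 and differs from it by the same change seen between compound 1 and compound 2: isopropyl in place of cyclohexyl on a carbonyl carbon. The place is the same in both pairs, a carbonyl carbon whose other neighbour is an amide-type nitrogen.

Expectation for compound 4 in this assay: a step of about the size seen from compound 1 to compound 2 is expected, that is a 1.3-fold higher number from compound 3 to compound 4 (0.11 log units; within the scatter), because the only measured instance of this change, a 1.3-fold higher number from compound 1 to compound 2 (0.12 log units; within the scatter), lies within the scatter. Among the measured compounds shown here, it is possible that the change reads differently on the core of compound 3, since only one measured instance exists, and the range is set accordingly. The estimate for compound 4 is 100 nM, expected between 45 nM and 260 nM.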

Compound 4, half-maximal effective concentration: 95 nM
For compound 4 the middle estimate is 1.1-fold (0.02 log units) above the measured one; the range from low to high includes it.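

In this assay, isopropyl in place of cyclohexyl on a carbonyl carbon gives a 1.2-fold higher number from compound 3 to compound 4 (0.09 log units; within the scatter), so this core, like the core of compound 1, does not tell the two acyl groups apart. Set beside the earlier step, the change reads the same on both cores: the same change on two cores in this assay, a 1.3-fold higher number (0.12 log units; within the scatter) from compound 1 to compound 2 and a 1.2-fold higher number (0.09 log units; within the scatter) from compound 3 to compound 4, 1.1-fold (0.03 log units) apart, within the scatter of two such steps. This supports carrying the exchange between these two cores as a step within the scatter, but it rests on one pair per core and does not show that the same would hold on any other core or for any other acyl group.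

Every compound shown has either cyclohexyl or isopropyl on this carbonyl carbon, so it remains open how the series would respond to a phenyl ring, a longer straight chain or an amine-bearing chain at that place. The difference between the two cores also remains unresolved, since no step among these compounds breaks it down into a change in one place.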